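The source may report more compounds than this note shows. Statements on the series, on what has been measured and on what is new or still open speak of the compounds shown alone.

Measured so far in a functional assay on KG-1 cells (Homo sapiens) for antiproliferative activity, read by CCK-8 assay, with a stated time of 72 h; on this read-out lower numbers stand for stronger inhibition and higher numbers for weaker inhibition:
- compound 1 `C=CC(=O)Nc1ccc(-n2nc3c(=O)[nH]nc(N)c3c2-c2oc3ccc(C)cc3c2C)cc1`: < 0.3 nM
- compound 2 `Cc1c(-c2c3c(N)n[nH]c(=O)c3nn2-c2ccccc2)oc2ccccc12`: 1110 nM

Compound 1 stands at the strong end of the two readings, and its < 0.3 nM is a limit of the assay and not a number. Compound 2 gives 1110 nM, a much weaker reading than that of compound 1.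

Compound 3 `Cc1ccc2oc(-c3c4c(N)n[nH]c(=O)c4nn3-c3ccc(NC(=O)/C=C/CN(C)C)cc3)c(C)c2c1` has not yet been measured. It departs from compound 1 in one place: 3-(dimethylamino)prop-1-en-1-yl in place of vinyl on a carbonyl carbon. In words, 3-(dimethylamino)prop-1-en-1-yl stands in place of vinyl on a carbonyl carbon, while the rest of the structure stays the same.

Among the compounds with values here, no measured pair of compounds tests this change, so any forecast for this assay is uncertain. The forecast starts from compound 1 at < 0.3 nM, which is a limit. A modest weakening is expected, somewhat beyond the usual scatter, and the estimated change is an at least 3.3-fold higher number from compound 1 to compound 3 (0.52 log units; beyond the scatter). Compound 3 is estimated at 1 nM, with an expected range of 0.15 nM to 8 nM.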

Compound 3, half-maximal inhibitory concentration: < 0.3 nM
Compound 3: only a limit was reported (the forecaster's own chance of this, stated with the estimate: 30%); middle value at least 3.3-fold (0.52 log units) away from the limit.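

In this assay compound 3 gives < 0.3 nM, which is a limit and not a number. Compound 1 also stands at a limit, so no step can be read between compound 1 and compound 3: the limit of < 0.3 nM in this assay, at which 2 of the 3 values shown sit. The compounds shown leave open whether 3-(dimethylamino)prop-1-en-1-yl in place of vinyl on a carbonyl carbon changes the reading at all.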